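This account rests on a few compounds, and the source may have more. Where it says the series, first, only, none or still open, it means among the compounds named here.

The series is read in an assay on Sf9 cells for inhibition of protein deacetylase HDAC6 (Homo sapiens), read by fluorescence, with a stated time of 40 min, tested at 100 nM; a lower number here means less inhibition, a higher number more inhibition at the concentration tested (going by the name of the read-out). Compound 1 `Cc1ccc(-c2nc(CNc3ccc(C(=O)NO)cc3)n(-c3ccccc3)n2)cc1` gives 62.2% there, the second highest of the three numbers recorded. Compound 2 `O=C(NO)c1ccc(NCc2nc(-c3ccccc3)nn2-c2ccc(F)cc2)cc1` gives 67.6%, a result that lies within the scatter of compound 1, so the two cannot be told apart. Compound 3 `Nc1ccccc1NC(=O)c1ccc(NCc2nc(-c3ccccc3)nn2-c2ccccc2)cc1` gives 5%, a number far below compound 1 and well beyond the scatter. Compound 4 `CCc1ccc(-c2nc(CNc3ccc(C(=O)NO)cc3)n(-c3ccccc3)n2)cc1` has not yet been measured. Relative to compound 1 it carries the change (methyl in place of hydrogen on a saturated chain carbon bound to an aromatic carbon), which one bond further out reads methyl to ethyl. Within the data shown here, no measured pair differs in only this way, so the expectation rests on the change itself. The step of a number 0.2 percentage points lower from compound 1 to compound 4 (within the scatter) is expected to be small, not beyond the scatter, in either direction. Compound 4 is therefore estimated at 62%, with a range from 46% to 78%.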

Compound 4, a percentage reported as inhibition, at one concentration (the size of the read-out at that concentration, not a potency): 54.6%
Beside the measured number, compound 4's estimate is 7.4 percentage points above it; low and high end bracket the measured number.
By their numbers in this assay, from the lowest: compound 3; then compounds 4, 1 and 2 (each within the scatter of the next, the first and the last beyond it).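

In this assay, among these compounds, lengthening methyl to ethyl on the 4-methylphenyl group gives the first reading at this position, a step of a number 7.6 percentage points lower from compound 1 to compound 4 (within the scatter), so 4-ethylphenyl and 4-methylphenyl cannot be told apart at the concentration tested. The one added carbon thus leaves the inhibition within the scatter here, though this rests on a single pair. No measurement offered here explains the result.

Going by these compounds, whether a longer chain such as butyl would keep the step this small remains open. So does the effect of an amine or a carboxylic acid at this place.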